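This account rests on a few compounds, and the source may have more. Where it says the series, first, only, none or still open, it means among the compounds named here.

Working notes on the series, read in an ADME assay on BHK-21 cells (Mesocricetus auratus) for cytotoxicity, with a stated time of 3 days; a higher number here means that more compound is tolerated, a lower number that less compound is tolerated. Compound 3, `O=C(CSc1nnc(-c2ccncc2)s1)Nc1ccc(Cl)cc1`, gives > 50000 nM, which is a limit and not a number. Compound 1, `CC(Sc1nnc(-c2ccncc2)s1)C(=O)Nc1ccccc1Cl`, gives > 50000 nM, also a limit, and it too carries 2-chlorophenyl on an amide-type nitrogen. For compound 2, `O=C(CSc1nnc(-c2ccncc2)s1)NCc1ccccc1Cl`, the entry reads "not determined" (no result reported). Among the measured compounds shown here, the standing of compound 3 therefore rests on (the limit of > 50000 nM in this assay, at which 2 of the 3 values shown sit), and no measured step joins any two compounds.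

Compound 4, `O=C(CSc1nnc(-c2ccncc2)s1)Nc1ccccc1Cl`, is still unmeasured. It has 2-chlorophenyl in place of 4-chlorophenyl on an amide-type nitrogen, (2-chlorophenyl in place of 4-chlorophenyl on an amide-type nitrogen). For the measured compounds named here, with no measured step to draw on, no change beyond the usual scatter is expected in this assay, in either direction. The estimated move is a number no higher from compound 3 to compound 4 (the limit leaves the size open). Compound 4 is expected at 50000 nM, with an estimated range from 20000 nM to 100000 nM.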

Compound 4, half-maximal cytotoxic concentration: > 50000 nM
Compound 4: only a limit was reported; the forecaster's own chance of this, stated with the estimate: 80%; the middle value lies on the limit itself.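

In this assay compound 4 gives > 50000 nM, which is a limit and not a number. Compound 1 and compound 3 also carry limits, so neither step to compound 4 can be read. The compounds shown leave open the concentration at which any of them stops being tolerated: the limit of > 50000 nM in this assay, at which 3 of the 4 values shown sit.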